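Ethoxy in Place of Fluoro: From Compound 3 to Compound 4

This account rests on a few compounds, and the source may have more. Where it says the series, first, only, none or still open, it means among the compounds named here.

Compound 1 `N#CC1=C(N)Oc2c(c3nc4ccccc4nc3c3ccccc23)C12C(=O)N(Cc1cnnn1-c1cccc(Cl)c1)c1ccccc12` was tested in an ADME assay on HUVEC cells (Homo sapiens) for antiproliferative activity, read by MTT assay, with a stated time of 48 h; a lower number here means a stronger inhibitor, a higher number a weaker inhibitor. In this assay compound 1 reaches only the limit of > 50000 nM. Compound 2 `Cc1ccc(Cl)cc1-n1nncc1CN1C(=O)C2(C(C#N)=C(N)Oc3c2c2nc4ccccc4nc2c2ccccc32)c2ccccc21` differs by methyl in place of hydrogen on an aromatic carbon, and compound 2 also gives only the limit of > 50000 nM, so the step that the two limits leave unreadable from compound 1 to compound 2 cannot be sized. Compound 3 `N#CC1=C(N)Oc2c(N)cc3nc4ccccc4nc3c2C12C(=O)N(Cc1cnnn1-c1ccc(F)cc1)c1ccccc12` likewise returns only the limit of > 50000 nM. Compound 3 thus stands where every measured value rests, because of the limit of > 50000 nM in this assay, at which 3 of the 3 values shown sit. Compound 4 `CCOc1ccc(-n2nncc2CN2C(=O)C3(C(C#N)=C(N)Oc4c(N)cc5nc6ccccc6nc5c43)c3ccccc32)cc1` carries the change (ethoxy in place of fluoro on an aromatic carbon). No readable step bears on this change, so no movement beyond the scatter is expected, and compound 4 is estimated at 50000 nM, between 20000 nM and 100000 nM, a step of a number no higher from compound 3 to compound 4 (the limit leaves the size open).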

Compound 4, half-maximal inhibitory concentration: > 50000 nM
Compound 4: a limit, no number (the forecaster's own chance of this, stated with the estimate: 85%); the middle value lies on the limit itself.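

Compound 3 and compound 4 both give only limits, and the step between them cannot be read. The compounds shown leave open how strongly any of them acts in this assay, and whether any change among them shifts the result.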